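This account rests on a few compounds, and the source may have more. Where it says the series, first, only, none or still open, it means among the compounds named here.

Measured so far:
compound 1 `Nc1nc(Cl)c2ncn(Cc3cccc(CCl)c3)c2n1` gives 4780 nM
compound 2 `ClCc1ccccc1Cn1cnc2c(Cl)ncnc21` gives 1580 nM
compound 3 `ClCc1ccc(Cn2cnc3ncnc(Cl)c32)cc1` gives "not determined" (no result reported), that is, no result reported

Both numbers come from a functional assay on MOLT-4 cells (Homo sapiens) for cytotoxicity, read by sulforhodamine B assay, with a stated time of 48 h; a higher number here means a weaker inhibitor of growth, a lower number a stronger inhibitor of growth. Of the two, compound 2 shows the lower value, compound 1 the higher; the two differ in more than one place, so nothing is drawn from the gap between them. Compound 3 stands on no number at all in this assay: no result is reported for it, so there is no anchor for the next step.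

Compound 4 `ClCc1ccc(Cn2cnc3nc(Cl)nc(Cl)c32)cc1` differs from compound 3 in one place: chloro in place of hydrogen on an aromatic carbon. A chloro enters where a hydrogen leaves, on the shared core. For the measured compounds named here, no measured pair isolates this change, and compound 3 itself is without a value, so the size of the step in this assay cannot be read from the data. The expectation is a step of no more than the usual scatter in either direction, with compound 4 landing near the range set by compound 1 and compound 2. Compound 4 is estimated at 3000 nM in this assay, with a range from 800 nM to 12000 nM.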

Compound 4, concentration for 50% growth inhibition: 1380 nM
Compound 4: the middle estimate sits 2.2-fold (0.34 log units) above what was measured, within the range that was stated.
By their numbers in this assay, from the lowest: compounds 4 and 2 (each within the scatter of the next); then compound 1.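

In this assay, for the compounds shown here, compound 4 gives 1380 nM but compound 3 carries no number, so no step between compound 3 and compound 4 can be read. The compounds shown leave open what the chloro group entering on the shared core does to growth inhibition. No supporting data bear on this result.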